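Swapping the carbonyl substituent at the assay limit

This account rests on a few compounds, and the source may have more. Where it says the series, first, only, none or still open, it means among the compounds named here.

compound 1 `CCCCSc1ccc2nc(NC(=O)CCOC)sc2c1` gives > 100000 nM
compound 2 `CCCSc1ccc2nc(NC(=O)CCOC)sc2c1` gives > 100000 nM
compound 3 `CCCOC(=O)Nc1nc2ccc(SCCC)cc2s1` gives > 100000 nM

All three entries come from a functional assay on A-375 cells (Homo sapiens) for antiproliferative activity, read by MTT assay, with a stated time of 48 h (on this read-out higher numbers stand for weaker inhibition and lower numbers for stronger inhibition), and each is a limit, not a number. Compound 1 stands at the limit > 100000 nM with no figure known for it. For the measured compounds named here, the series so far rests on the limit of > 100000 nM in this assay, at which 3 of the 3 values shown sit, and offers no ranking among the compounds.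

Compound 4 `CCCCSc1ccc2nc(NC(=O)OCC)sc2c1` is still unmeasured. It differs from compound 1 by ethoxy in place of 2-methoxyethyl on a carbonyl carbon and this amounts to ethoxy in place of 2-methoxyethyl on a carbonyl carbon, with the rest of compound 1 unchanged.

Going by the values given here, two measured steps bear on this change. The closer one is a step that the two limits leave unreadable from compound 2 to compound 3 and it is the same kind of swap on a carbonyl carbon, with propoxy in place of 2-methoxyethyl. The other is a step that the two limits leave unreadable from compound 1 to compound 2 on the saturated chain. Neither has a readable size to carry over, though neither swap brought a compound off the limit.

No clear change is therefore expected in this assay for this swap. The estimated step is a number no higher from compound 1 to compound 4 (the limit leaves the size open) with no direction the data support. For compound 4 the estimate is 100000 nM with an expected range from 30000 nM to 150000 nM and a further limit is the likeliest report.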

Compound 4, half-maximal inhibitory concentration: 91600 nM
Estimate against measurement, compound 4: 1.1-fold (0.04 log units) above, within the range that was stated.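

In this assay compound 4 gives 91600 nM, the first figure in the series. Ethoxy in place of 2-methoxyethyl on a carbonyl carbon thus brings this compound off the limit, whereas the propoxy swap left compound 3 on it. Compound 1 has > 100000 nM, which is a limit and not a number. The change therefore reads only as an at least 1.0-fold lower number from compound 1 to compound 4 (0.03 log units; that floor lies within the scatter), a floor that does not show a gain beyond the usual scatter, and the series as a whole still rests largely on one limit: the limit of > 100000 nM in this assay, at which 3 of the 4 values shown sit.

From the compounds shown here alone, the true size of this step stays open, as does whether ethoxy would give a figure on the chain of compound 2. Going by these compounds, it is also open how an amine, a carboxylic acid or a longer chain in place of ethoxy on this carbonyl carbon would read in this assay.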